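Cytotoxicity in Vero Cells Across Three Measured Compounds

The compounds below may be only part of what the source reports. "The series", "measured", "known", "first", "only" and "open" are said of these compounds alone.

Compound 1 `O=c1cc(Nc2ccccc2)sc2c([N+](=O)[O-])cc(C(F)(F)F)cc12`: > 64 ug/mL
Compound 2 `O=C1CN(c2cc(=O)c3cc(C(F)(F)F)cc([N+](=O)[O-])c3s2)CCN1CC1CCCCC1`: > 64 ug/mL
Compound 3 `O=c1cc(N2CCN(c3nccs3)CC2)sc2c([N+](=O)[O-])cc(C(F)(F)F)cc12`: > 64 ug/mL

In an ADME assay on Vero cells (Chlorocebus sabaeus) for cytotoxicity, read by MTT assay, with a stated time of 48 h (a lower number here means a stronger inhibitor, a higher number a weaker inhibitor), compound 3 gives > 64 ug/mL, and this is a limit of the assay rather than a measured number. Compound 1 likewise gives > 64 ug/mL, a limit. Compound 2 gives > 64 ug/mL, again a limit. So no compound measured so far has a true number in this assay, and compound 3 cannot be ranked against the others: all three simply sit at the limit of > 64 ug/mL in this assay, at which 3 of the 3 values shown sit.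

The next compound, compound 4 `O=c1cc(N2CCN(CC3CCCCC3)CC2)sc2c([N+](=O)[O-])cc(C(F)(F)F)cc12`, differs from compound 3 in one place: cyclohexylmethyl in place of 1,3-thiazol-2-yl on an amine nitrogen in a ring. The group that enters is the same cyclohexylmethyl that compound 2 carries on its own ring nitrogen, and compound 2 reached only the limit in this assay.

Among the measured compounds shown here, no measured step between these compounds is available, so the expectation rests on the limits alone. The step from compound 3 to compound 4 is expected to be none beyond the scatter, a step that the limit leaves unreadable from compound 3 to compound 4, because every value shown sits at the limit of > 64 ug/mL in this assay, at which 3 of the 3 values shown sit. Compound 4 is therefore estimated at 100 ug/mL, within a range of 50 ug/mL to 200 ug/mL, most likely reported again as a limit.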

Compound 4, half-maximal inhibitory concentration: > 64 ug/mL
Compound 4: no number, only a limit (the forecaster's own chance of this, stated with the estimate: 85%); the middle value is on the limit's open side.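

No step can be read between compound 3 and compound 4, since neither gives a true number in this assay: the limit of > 64 ug/mL in this assay, at which 4 of the 4 values shown sit.

The compounds shown leave open at what concentration any of the four would become toxic to these cells, and whether cyclohexylmethyl in place of 1,3-thiazol-2-yl changes that concentration at all.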